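Replacing the nitro of compound 1 with methyl

The compounds below may be only part of what the source reports. "The series", "measured", "known", "first", "only" and "open" are said of these compounds alone.

Compound 1 `COc1cc(-n2cnc3ccc(-c4ccc([N+](=O)[O-])cc4)cc32)cc(OC)c1OC`: 79 nM
Compound 2 `COc1ccccc1-c1ccc2ncn(-c3cc(OC)c(OC)c(OC)c3)c2c1`: 5050 nM
Compound 3 `COc1cc(-n2cnc3ccc(-c4ccc(Cl)cc4Cl)cc32)cc(OC)c1OC`: > 10000 nM

In a functional assay on SGC-7901 cells (Homo sapiens) for antiproliferative activity, read by MTT assay, with a stated time of 72 h (a lower number here means a stronger inhibitor, a higher number a weaker inhibitor), compound 1 gives 79 nM, the lowest of the two numbers shown. Compound 2 gives 5050 nM. For compound 3 the assay reports only a limit, > 10000 nM (the limit of > 10000 nM in this assay, at which 1 of the 3 values shown sits). Compound 4 `COc1cc(-n2cnc3ccc(-c4ccc(C)cc4)cc32)cc(OC)c1OC` is not yet measured; it differs from compound 1 by methyl in place of nitro on an aromatic carbon. For the measured compounds named here, two measured steps bear on this change: a 64-fold higher number from compound 1 to compound 2 (1.81 log units; beyond the scatter) and an at least 120-fold higher number from compound 1 to compound 3 (2.10 log units; beyond the scatter), both large losses on exchanging the 4-nitrophenyl. The change to compound 4 keeps a group on the same aromatic carbon, so a smaller loss than those is expected, though still a step beyond the scatter toward a higher number. Compound 4 is therefore estimated at 1000 nM, between 150 nM and 8000 nM, meaning a 13-fold higher number from compound 1 to compound 4 (1.10 log units; beyond the scatter).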

Compound 4, half-maximal inhibitory concentration: 200 nM
Compound 4: middle estimate off by 5.0-fold (0.70 log units), on the high side, within the range that was stated.
By their numbers in this assay, from the lowest: compound 1; then compound 4; then compound 2. At a limit, above all of these: compound 3.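

In this assay, methyl in place of nitro costs far less than the earlier exchanges of the 4-nitrophenyl, with a 2.5-fold higher number from compound 1 to compound 4 (0.40 log units; beyond the scatter), so a nitro group is not required for a low number at this position. The 4-methylphenyl also stands clear of the other two aryl groups, with a 25-fold lower number from compound 2 to compound 4 (1.40 log units; beyond the scatter) and an at least 50-fold lower number from compound 3 to compound 4 (1.69 log units; beyond the scatter), so the large losses of compound 2 and compound 3 do not follow from losing the nitro alone. The step from compound 3 rests on a limit: the limit of > 10000 nM in this assay, at which 1 of the 4 values shown sits.

As far as these compounds go, whether an amine, a carboxylic acid or a longer chain on the same carbon would match methyl or nitro stays open. Two groups at this place give no trend.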